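This account rests on a few compounds, and the source may have more. Where it says the series, first, only, none or still open, it means among the compounds named here.

The measured compounds and their values in a functional assay on ONS-76 cells (Homo sapiens) for cytotoxicity, read by MTT assay, with a stated time of 72 h; a lower number here means a stronger inhibitor, a higher number a weaker inhibitor:
Compound 1, `COc1ccc(N(C)C(=O)N(C)c2cc(OC)c(OC)c(OC)c2)cc1`, gives >= 125000 nM.
Compound 2, `COc1cc(N(C)C(=O)N(C)c2ccc([N+](=O)[O-])cc2)cc(OC)c1OC`, gives >= 125000 nM.
Compound 3, `COc1cc(N(C)C(=O)c2ccc([N+](=O)[O-])cc2)cc(OC)c1OC`, gives >= 125000 nM.

Each of these three values is a limit of this assay, not a number; (the limit of >= 125000 nM in this assay, at which 3 of the 3 values shown sit). Compound 2 and compound 1 differ by methoxy in place of nitro on an aromatic carbon, and the step that the two limits leave unreadable from compound 2 to compound 1 is left unreadable by the two limits. Compound 4, `COc1ccc(C(=O)N(C)c2cc(OC)c(OC)c(OC)c2)cc1`, has not yet been measured; it differs from compound 3 by methoxy in place of nitro on an aromatic carbon, the same change, at a place described in the same words. The difference between the core of compound 3 and that of compound 2 is not broken down here. Compound 3 itself gives >= 125000 nM, which is a limit of this assay. Because the step that the two limits leave unreadable from compound 2 to compound 1 cannot be read, the step of a number no higher from compound 3 to compound 4 (the limit leaves the size open) is expected to be small. Compound 4 is therefore estimated at 125000 nM, most likely again reported only as a limit, between 30000 nM and 300000 nM.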

Compound 4, half-maximal inhibitory concentration: >= 125000 nM
Compound 4 ended at the assay's limit (the forecaster's own chance of this, stated with the estimate: 75%); the middle value sits exactly at the limit.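

In this assay compound 4 gives >= 125000 nM, which is a limit and not a number. No step can be read between compound 3 and compound 4. The compounds shown leave open whether methoxy in place of nitro on an aromatic carbon changes the value at all.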